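Working notes on a cytotoxicity series with one compound pending

The compounds below may be only part of what the source reports. "The series", "measured", "known", "first", "only" and "open" are said of these compounds alone.

In a functional assay on Bel-7402 cells (Homo sapiens) for cytotoxicity, read by MTT assay (a higher number here means a weaker inhibitor, a lower number a stronger inhibitor), compound 1 `Cc1nc(Nc2cccc(Cl)c2)sc1C(=O)/C=C/c1ccccc1` gives only a limit, > 25000 nM. Compound 2 `Cc1ccccc1Nc1nc(C)c(C(=O)/C=C/c2ccccc2)s1` likewise stops at a limit, > 25000 nM. Compound 3 `COc1cccc(/C=C/C(=O)c2sc(Nc3ccccc3C)nc2C)c1` also reaches only a limit, > 25000 nM. The difference between the cores of compound 2 and compound 3 is methoxy in place of hydrogen on an aromatic carbon. The change 3-chlorophenyl in place of 2-methylphenyl on a nitrogen on an aromatic ring gives a step that the two limits leave unreadable from compound 2 to compound 1, and the change from compound 2 to compound 3 gives a step that the two limits leave unreadable from compound 2 to compound 3. All three values rest at the limit of > 25000 nM in this assay, at which 3 of the 3 values shown sit. Compound 4 `COc1cccc(/C=C/C(=O)c2sc(Nc3cccc(Cl)c3)nc2C)c1` is not yet measured; it differs from compound 3 by 3-chlorophenyl in place of 2-methylphenyl on a nitrogen on an aromatic ring, the same kind of change as from compound 2 to compound 1, at the same place. The expected step is a step that the limit leaves unreadable from compound 3 to compound 4, resting on compound 1 and compound 2 both sitting at the limit of > 25000 nM in this assay, at which 3 of the 3 values shown sit. Compound 4 is expected to give 40000 nM in this assay, most probably again only a limit.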

Compound 4, half-maximal inhibitory concentration: > 25000 nM
Compound 4 was reported as a limit (the forecaster's own chance of this, stated with the estimate: 85%); the middle value does not contradict the limit.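

No step can be read from compound 3 to compound 4 or from compound 1 to compound 4, because all these values are only limits: the limit of > 25000 nM in this assay, at which 4 of the 4 values shown sit.

The compounds shown leave open how strongly any of the four acts in this assay, and so whether either change has any effect there.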